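The source may report more compounds than this note shows. Statements on the series, on what has been measured and on what is new or still open speak of the compounds shown alone.

Measured so far:
- compound 1 `CC(C)S(=O)(=O)n1cc2c(n1)CN([C@H]1CO[C@H](c3cc(F)ccc3F)[C@@H](N)C1)C2` at 7 mL/min/kg
- compound 2 `CCC(=O)Nc1n[nH]c2c1CN([C@H]1CO[C@H](c3cc(F)ccc3F)[C@@H](N)C1)C2` at 60 mL/min/kg
- compound 3 `N[C@H]1C[C@@H](N2Cc3[nH]nc(NC(=O)C4CC4)c3C2)CO[C@@H]1c1cc(F)ccc1F` at 64 mL/min/kg

All three were measured in an ADME assay on the whole organism (plasma) for pharmacokinetics, with Rattus norvegicus as the target; on this read-out higher numbers stand for fast clearance and lower numbers for slow clearance. Compound 3 gives 64 mL/min/kg, which is level with compound 2 within the scatter and far above compound 1.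

Compound 4 `CS(=O)(=O)Nc1n[nH]c2c1CN([C@H]1CO[C@H](c3cc(F)ccc3F)[C@@H](N)C1)C2` alters one group of compound 3 : methylsulfonyl in place of cyclopropylcarbonyl on a nitrogen on an aromatic ring. In short, methylsulfonyl takes the place of cyclopropylcarbonyl on a nitrogen on an aromatic ring.

For the measured compounds named here, only one measured step touches this group, a 1.1-fold higher number from compound 2 to compound 3 (0.03 log units; within the scatter). It stayed within the scatter, but it swapped ethyl for cyclopropyl and kept the carbonyl, so it says little about removing the carbonyl. Going by the values given here, no measured step makes that exchange. Compound 1 also carries a sulfonyl group and gives 7 mL/min/kg, yet it differs from compound 3 in more than one place, so it offers only a weak hint towards a lower number.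

The expected change is modest and downward, a 1.6-fold lower number from compound 3 to compound 4 (0.20 log units; within the scatter), and may not clear the scatter. For compound 4 the estimate is 40 mL/min/kg, with an expected range of 15 mL/min/kg to 80 mL/min/kg.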

Compound 4, clearance: 16 mL/min/kg
Compound 4: middle estimate off by 2.5-fold (0.40 log units), on the high side; measured number inside the range.
By their numbers in this assay, from the lowest: compound 1; then compound 4; then compounds 2 and 3 (each within the scatter of the next).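

For the compounds shown here, at this nitrogen on an aromatic ring, the earlier compounds compared only two carbonyl groups, and exchanging ethyl for cyclopropyl there stayed within the scatter. In this assay, exchanging the whole carbonyl group for methylsulfonyl has a larger effect: cyclopropylcarbonyl to methylsulfonyl gives a 4.0-fold lower number from compound 3 to compound 4 (0.60 log units; beyond the scatter), and propanoyl to methylsulfonyl gives a 3.8-fold lower number from compound 2 to compound 4 (0.57 log units; beyond the scatter), so both comparisons point the same way and both lie beyond the scatter. Nothing available here explains this shift in clearance.

The compounds shown leave open whether the lower number would hold with a longer chain on the sulfonyl, such as ethylsulfonyl or propylsulfonyl. They also leave open what a plain amine at this place would give, with neither a carbonyl nor a sulfonyl group attached.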